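Aryl variation on the shared core: expectation for compound 4

The source may hold more compounds than are shown below. What is called first, only, known or untested is meant among the compounds shown, and "the series" means these compounds.

Measured so far in an assay on membranes from brain for displacement of a labelled ligand from Sigma non-opioid intracellular receptor 1 (Cavia porcellus), read by scintillation counting, with a stated time of 120 min; a higher number here means a weaker inhibitor, a lower number a stronger inhibitor:
compound 1 `O=[N+]([O-])c1ccc(-c2scc3c2CCOC32CCN(Cc3ccccc3)CC2)cc1` gives 1.7 nM
compound 2 `COC1Cc2c(csc2-c2ccc(C)cc2)C2(CCN(Cc3ccccc3)CC2)O1` gives 2 nM
compound 3 `COC1Cc2c(csc2-c2cccc3ccccc23)C2(CCN(Cc3ccccc3)CC2)O1` gives 5 nM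

Compound 3 carries the highest number of the three; compound 2 sits a step below it, and compound 1 further below still. Going by the values given here, the only measured step at the aryl position, a 2.5-fold higher number from compound 2 to compound 3 (0.40 log units; beyond the scatter), is modest but beyond the scatter. Compound 4 `COC1Cc2c(csc2-c2ccc([N+](=O)[O-])cc2)C2(CCN(Cc3ccccc3)CC2)O1` differs from compound 3 by 4-nitrophenyl in place of naphthalen-1-yl on an aromatic carbon. Among the compounds with values here, no measured pair covers this exact exchange on the methoxy-bearing core; compound 1 holds the same 4-nitrophenyl group on the core without the methoxy and gives 1.7 nM, a number below that of compound 3. Taken together with a 2.5-fold higher number from compound 2 to compound 3 (0.40 log units; beyond the scatter), a lower number is expected for compound 4, by a 2.5-fold lower number from compound 3 to compound 4 (0.40 log units; beyond the scatter), with an estimate of 2 nM and a range of 1 nM to 5 nM.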

Compound 4, inhibition constant: 1 nM
Compound 4: the middle estimate sits 2.0-fold (0.30 log units) above what was measured; the range from low to high includes it.
By their numbers in this assay, from the lowest: compounds 4, 1 and 2 (each within the scatter of the next); then compound 3.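

In this assay, 4-nitrophenyl in place of naphthalen-1-yl gives a 5.0-fold lower number from compound 3 to compound 4 (0.70 log units; beyond the scatter), the largest step yet seen at this aromatic carbon. Nitro in place of methyl gives a 2.0-fold lower number from compound 2 to compound 4 (0.30 log units; within the scatter), and methoxy in place of hydrogen on a saturated ring carbon gives a 1.7-fold lower number from compound 1 to compound 4 (0.23 log units; within the scatter); both lie within the scatter. On the shared core, 4-methylphenyl and 4-nitrophenyl therefore do not separate, and only naphthalen-1-yl stands apart from them.

On these data alone, whether an amine or a carboxylic acid in place of nitro would keep the number this low remains open. No supporting data on any property of these groups are available to explain the steps.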